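A few compounds are considered here, and "the series" means these few. Any claim that something is new, unique, unknown or untested is made for them only; others in the source may bear on it.

Measured compounds:
compound 1, `Cc1ccc(CNC(=S)Nc2ccc(C(=O)Nc3ccccc3N)cc2)cn1`, > 2000 nM
compound 2, `Nc1ccccc1NC(=O)c1ccc(NC(=S)NCc2cncc(F)c2)cc1`, > 2000 nM
compound 3, `Nc1ccc(CNC(=O)Nc2ccc(C(=O)Nc3ccccc3N)cc2)cn1`, > 2000 nM

Each of these three values in an assay on isolated protein for inhibition of Nicotinamide phosphoribosyltransferase (Homo sapiens), read by fluorescence, with stated times of 5 min and 15 min (on this read-out lower numbers stand for stronger inhibition and higher numbers for weaker inhibition), is a limit of the assay rather than a number. Compound 2 stands at such a limit, and the limit of > 2000 nM in this assay, at which 3 of the 3 values shown sit, tells where all the shown values sit. Among the compounds with values here, the only measured step, a step that the two limits leave unreadable from compound 1 to compound 2, runs between two limits, so its size is not readable. Compound 4, `Nc1ccccc1NC(=O)c1ccc(NC(=S)NCc2cccc(Cl)c2)cc1`, differs from compound 2 by 3-chlorophenyl in place of 5-fluoropyridin-3-yl on a saturated chain carbon bound to an amide-type nitrogen. Within the data shown here, no measured step shows what this change does. With every shown value at the limit, compound 4 is expected to remain there as well, which amounts to an estimated step that the limit leaves unreadable from compound 2 to compound 4. The estimate for compound 4 in this assay is 3000 nM, with a range from 1000 nM to 10000 nM.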

Compound 4, half-maximal inhibitory concentration: > 2000 nM
Compound 4 was reported as a limit; the forecaster's own chance of this, stated with the estimate: 75%; the middle value lies beyond the limit too.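

Compound 4 gives only a limit of the assay, as do compound 1 and compound 2, so no step among them can be read: the limit of > 2000 nM in this assay, at which 4 of the 4 values shown sit.

The compounds shown leave open how strongly each acts in this assay, and whether swapping the ring on this chain carbon changes that at all.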